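The compounds below may be only part of what the source reports. "The series", "measured", "known", "first", "only" and "open" are said of these compounds alone.

In an ADME assay on L02 cells (Homo sapiens) for cytotoxicity, read by MTT assay (a lower number here means a stronger inhibitor, a higher number a weaker inhibitor), compound 2 `COc1ccc(/C=C/C(=O)c2ccc(OC)c3c2OC(C)(C)C=C3)cc1OC(=O)c1ccco1` gives > 10000 nM, which is a limit of the assay and not a number. Compound 1 `C=CCOc1cc(/C=C/C(=O)c2ccc(OC)c3c2OC(C)(C)C=C3)ccc1OC` gives > 20000 nM, and this is also a limit. Within the data shown here, compound 2 therefore has no exact place on the scale, and neither of the two compounds measured so far has a number to compare.

Compound 3 `COc1ccc(/C=C/C(=O)c2ccc(OC)c3c2OC(C)(C)C=C3)cc1OS(=O)(=O)c1ccc(C)cc1` keeps the shared core and changes one group: (4-methylphenyl)sulfonyl in place of (furan-2-yl)carbonyl on an oxygen on an aromatic ring. Here (4-methylphenyl)sulfonyl takes the place of (furan-2-yl)carbonyl on an oxygen on an aromatic ring. One measured step changes a group at this same place, and it is a step that the two limits leave unreadable from compound 1 to compound 2. Both of its ends are limits, so it offers no size to carry over to the new change. With no measured size to go on, no step beyond the usual scatter is expected in this assay, and no direction can be favoured. The estimated step is a step that the limit leaves unreadable from compound 2 to compound 3. For compound 3 the expected value is 15000 nM, with an estimated range from 6000 nM to 40000 nM.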

Compound 3, half-maximal inhibitory concentration: > 10000 nM
Compound 3 ended at the assay's limit; the forecaster's own chance of this, stated with the estimate: 75%; the middle value does not contradict the limit.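

Compound 3 gives > 10000 nM in this assay, which is a limit and not a number. Among these compounds, compound 1 and compound 2 also stand at limits, so no step among the three can be read. The compounds shown leave open whether allyl, (furan-2-yl)carbonyl and (4-methylphenyl)sulfonyl on an oxygen on an aromatic ring differ at all in this assay.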